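Moving from Methylphenyl to Fluorophenyl: an Expected Limit

This account rests on a few compounds, and the source may have more. Where it says the series, first, only, none or still open, it means among the compounds named here.

Measured so far, in a functional assay on A549 cells (Homo sapiens) for antiproliferative activity, read by MTT assay, with a stated time of 24 h; on this read-out lower numbers stand for stronger inhibition and higher numbers for weaker inhibition:
Compound 1 `O=C(NNc1ccc(F)cc1)c1ccccc1NS(=O)(=O)c1cnc(O)nc1O` gives > 20000 nM, which is a limit of the assay rather than a number.
Compound 2 `Cc1ccc(C(=O)NNC(=O)c2ccccc2NS(=O)(=O)c2cnc(O)nc2O)cc1` gives > 20000 nM, again only a limit.

Compound 2 therefore stands on no number at all: both values shown sit at the same limit (the limit of > 20000 nM in this assay, at which 2 of the 2 values shown sit). For the measured compounds named here, the single measured step, a step that the two limits leave unreadable from compound 1 to compound 2, has no readable size, as both of its ends are limits. Compound 3 `O=C(NNC(=O)c1ccccc1NS(=O)(=O)c1cnc(O)nc1O)c1ccccc1F` differs from compound 2 by 2-fluorophenyl in place of 4-methylphenyl on a carbonyl carbon. Going by the values given here, no measured step bears readably on this change, so no step beyond the scatter can be foreseen, and the most likely outcome is that compound 3 also stays at the limit in this assay. The estimated step that the limit leaves unreadable from compound 2 to compound 3 is thus expected to be essentially none. Compound 3 is estimated at 30000 nM, within 10000 nM to 100000 nM.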

Compound 3, half-maximal inhibitory concentration: 7150 nM
For compound 3 the middle estimate is 4.2-fold (0.62 log units) above the measured one; measured number below the stated range.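

In this assay, the group on this carbonyl carbon can move the read-out off the limit: 2-fluorophenyl in place of 4-methylphenyl gives an at least 2.7-fold lower number from compound 2 to compound 3 (0.44 log units; beyond the scatter). Compound 1, which carries 4-fluorophenyl on an amine nitrogen, gains a (2-fluorophenyl)carbonyl there in compound 3, and this change gives an at least 2.7-fold lower number from compound 1 to compound 3 (0.44 log units; beyond the scatter). Compound 3 is the only compound here with a true number, so both steps give only a smallest size and their full size remains unknown: the limit of > 20000 nM in this assay, at which 2 of the 3 values shown sit.

On these data alone, whether the lower number belongs to the fluorine itself or to its place on the phenyl ring remains open, as does the part played by losing the 4-methyl group. An unsubstituted phenyl, a 4-fluorophenyl or a 2-chlorophenyl on this carbonyl carbon would help to separate these possibilities.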